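The source may report more compounds than this note shows. Statements on the series, on what has been measured and on what is new or still open speak of the compounds shown alone.

Measured compounds:
compound 1 `C=CC(=O)Nc1cc(Nc2ncc3ncn(-c4ccc(Cl)cc4)c3n2)c(OC)cc1N(C)CCN(C)C` with 7690 nM
compound 2 `C=CC(=O)Nc1cc(Nc2ncc3ncn(-c4ccccc4Cl)c3n2)c(OC)cc1N(C)CCN(C)C` with 11300 nM

In an ADME assay on HT-29 cells (Homo sapiens) for cytotoxicity, read by MTT assay, with a stated time of 72 h (on this read-out lower numbers stand for stronger inhibition and higher numbers for weaker inhibition), compound 1 gives 7690 nM, the lower of the two numbers; compound 2 gives 11300 nM, and the step of a 1.5-fold higher number from compound 1 to compound 2 (0.17 log units; within the scatter) lies within the scatter, so the two cannot be ordered. Compound 3 `C=CC(=O)Nc1cc(Nc2ncc3ncn(-c4ccc(Cl)cc4Cl)c3n2)c(OC)cc1N(C)CCN(C)C` differs from compound 1 by chloro in place of hydrogen on an aromatic carbon. Going by the values given here, only one measured step is available, and it moves the single chloro group around the ring rather than adding a second one, so it bears on the new change only loosely; its size is small. Among the compounds with values here, with no step that speaks directly to a second chloro group, compound 3 is expected to give a step of a 1.2-fold higher number from compound 1 to compound 3 (0.07 log units; within the scatter) that does not go beyond the scatter. The estimate for compound 3 is therefore 9000 nM, with a range from 3500 nM to 25000 nM.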

Compound 3, half-maximal inhibitory concentration: 20600 nM
Compound 3: the middle estimate sits 2.3-fold (0.36 log units) below what was measured; the range from low to high includes it.
By their numbers in this assay, from the lowest: compounds 1, 2 and 3 (each within the scatter of the next, the first and the last beyond it).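

In this assay, adding a second chloro to the 4-chlorophenyl ring gives a 2.7-fold higher number from compound 1 to compound 3 (0.43 log units; beyond the scatter), the only step among these compounds that goes beyond the scatter, and it is modest in size. The same addition to the 2-chlorophenyl ring gives a 1.8-fold higher number from compound 2 to compound 3 (0.26 log units; within the scatter), so the 2,4-dichlorophenyl compound stands apart from the 4-chlorophenyl compound but not from the 2-chlorophenyl compound. Nothing measured here accounts for the step from the 4-chlorophenyl to the 2,4-dichlorophenyl group.

The compounds shown leave open whether this step belongs to chloro itself or would also appear with fluoro, methyl or methoxy at the same place on the ring. They also leave open how an amine or a carboxylic acid on that ring would read in this cell assay.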